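This account rests on a few compounds, and the source may have more. Where it says the series, first, only, none or still open, it means among the compounds named here.

Measured so far:
compound 1 `CC(C)c1ccc(OC(Cc2ccc3ccccc3c2)C(=O)O)cc1`, 50 mg/kg 
compound 2 `CCCc1cccc(CC(C)(Oc2ccc(C(C)C)cc2)C(=O)O)c1`, 1 mg/kg 
compound 3 `CCCCc1cccc(CC(C)(Oc2ccc(C(C)C)cc2)C(=O)O)c1`, 1 mg/kg 

In a functional assay on the whole organism for inhibition, with Rattus norvegicus as the target (on this read-out lower numbers stand for an effect already at smaller amounts and higher numbers for an effect only at larger amounts of compound), compound 1 gives 50 mg/kg, the highest of the three numbers; compound 2 gives 1 mg/kg and compound 3 gives 1 mg/kg. The difference between the core of compound 1 and the core of compound 2 is not broken down here.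

Within the shared core of compounds 2 and 3, the change methyl in place of hydrogen on a saturated chain carbon, three bonds along the chain from an aromatic carbon gives no change at the digits printed from compound 2 to compound 3 (within the scatter).

Compound 4 `CC(C)c1ccc(OC(C)(Cc2ccc3ccccc3c2)C(=O)O)cc1` is not yet measured. It differs from compound 1 by methyl in place of hydrogen on a saturated chain carbon bound to a carbonyl carbon, an oxygen on an aromatic ring and a saturated chain carbon. This is the same kind of change as between compounds 2 and 3, but at another place: there the methyl enters on a saturated chain carbon three bonds along the chain from an aromatic carbon, here on a saturated chain carbon bound to a carbonyl carbon, an oxygen on an aromatic ring and a saturated chain carbon. Among the compounds with values here, compounds 2 and 3 both carry a methyl at such a place and sit far below compound 1, yet no single measured step shows this change on its own. The step from compound 1 to compound 4 is expected to be a 5.0-fold lower number from compound 1 to compound 4 (0.70 log units; beyond the scatter), resting on compound 1 at 50 mg/kg and on the two lower numbers of compounds 2 and 3, with wide uncertainty. For compound 4 the estimate in this assay is 10 mg/kg, expected between 2 mg/kg and 40 mg/kg.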

Compound 4, dose for half-maximal effect: > 10 mg/kg
Compound 4: a limit, no number; the forecaster's own chance of this, stated with the estimate: 5%; the middle value lies on the limit itself.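

In this assay, within the data shown here, compound 4 gives > 10 mg/kg, a limit and not a number, so no step from compound 1 to compound 4 can be read. On these data alone, what methyl in place of hydrogen alone does to the core of compound 1 stays open in this assay.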